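Changing the Halogenated Phenyl on the Ring Nitrogen

The source may report more compounds than this note shows. Statements on the series, on what has been measured and on what is new or still open speak of the compounds shown alone.

Of the compounds shown here, two sharing one core have been measured in an assay on CHO cells for displacement of a labelled ligand from adenosine receptor A3 (Homo sapiens), read by scintillation counting, with a stated time of 45 min, tested at 1 uM, in the presence of a further agent that is not named here; a higher number here means more inhibition at the concentration tested (going by the name of the read-out), a lower number less inhibition. Compound 1 `CCCn1c(=O)[nH]c2nc(-c3ccc(S(=O)(=O)N4CCN(c5ccc(F)cc5)CC4)cc3)[nH]c2c1=O` carries a 4-fluorophenyl on an amine nitrogen in a ring, and in this assay compound 1 gives 38%. Compound 2 `CCCn1c(=O)[nH]c2nc(-c3ccc(S(=O)(=O)N4CCN(c5ccc(Cl)cc5F)CC4)cc3)[nH]c2c1=O` carries a 4-chloro-2-fluorophenyl at that place, and compound 2 gives 14%. That step is a number 24 percentage points lower from compound 1 to compound 2 (beyond the scatter), so compound 2 stands at the lower of the two numbers, beneath compound 1 by more than the usual scatter.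

Compound 3 `CCCn1c(=O)[nH]c2nc(-c3ccc(S(=O)(=O)N4CCN(c5ccc(Br)cc5)CC4)cc3)[nH]c2c1=O` has not been measured. Among the compounds with values here, it differs from compound 2 as follows: 4-bromophenyl in place of 4-chloro-2-fluorophenyl on an amine nitrogen in a ring The only measured step that bears on this change is a number 24 percentage points lower from compound 1 to compound 2 (beyond the scatter); there, a phenyl with a single fluorine was exchanged for one bearing chlorine and fluorine, and the number fell by a modest amount. Compound 3 returns to a phenyl with a single halogen, now bromine, so the number is expected to recover part of that loss. The estimated step is a number 16 percentage points higher from compound 2 to compound 3 (beyond the scatter), a move back toward the first number. Compound 3 is expected to give 30%, with a range from 10% to 50%.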

Compound 3, a percentage reported as inhibition, at one concentration (the size of the read-out at that concentration, not a potency): 29%
Estimate against measurement, compound 3: 1 percentage points above; measured number inside the range.
By their numbers in this assay, from the lowest: compound 2; then compounds 3 and 1 (each within the scatter of the next).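

In this assay, exchanging one halogen for another on the same aromatic carbon gives a number 9 percentage points lower from compound 1 to compound 3 (within the scatter), so fluoro and bromo at this place cannot be told apart here. The other new step, a number 15 percentage points higher from compound 2 to compound 3 (beyond the scatter), shows that the earlier fall does not follow every change away from the 4-fluorophenyl group: it appears with the 4-chloro-2-fluorophenyl group, and the 4-bromophenyl group does not share it. No supporting data accompany these numbers, so the reason for this pattern remains unknown.

The 4-chloro-2-fluorophenyl group of compound 2 differs from the 4-fluorophenyl group of compound 1 in two ways at once, with chlorine in place of the first fluorine and a further fluorine added, and a 4-chlorophenyl or a 2-fluorophenyl group would be needed to separate those two changes. Also open, as far as these compounds go, is how an unsubstituted phenyl or a 4-methoxyphenyl group would read at this place on the ring nitrogen, where only halogen-bearing phenyl groups appear so far.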